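Rearranging an Imidazole Substituent in a Bromoanisole Series

This account rests on a few compounds, and the source may have more. Where it says the series, first, only, none or still open, it means among the compounds named here.

Measured compounds:
- Compound 1, `COc1ccc(Br)cc1CCc1c(F)cccc1-c1ncc2n1CCC2`, gives 390 nM in a functional assay on HEK293 cells (Homo sapiens), read by cAMP accumulation; a higher number here means a weaker inhibitor, a lower number a stronger inhibitor.
- Compound 2, `CCc1cnc(-c2ccccc2CCc2cc(Br)ccc2OC)n1C`, gives 170 nM in this assay.
- Compound 3, `COc1ccc(Br)cc1CCc1ccccc1-c1nc(C(C)C)cn1C`, gives 1200 nM in this assay.

Among these three, compound 2 stands at the lowest number, and its steps to both compound 1 and compound 3 are beyond the usual scatter, so it is the strongest inhibitor of the set. All three share the same core, and they differ only in the small aromatic group carried on one of its rings.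

Compound 4, `COc1ccc(Br)cc1CCc1ccccc1-c1nc(C)c(C)n1C`, has not yet been measured. It differs from compound 2 in this way: 1,4,5-trimethyl-1H-imidazol-2-yl in place of 5-ethyl-1-methyl-1H-imidazol-2-yl on an aromatic carbon. The same atoms are simply arranged differently, with the ethyl split into two methyls on the five-membered ring.

Without a measured pair of this exact kind, the expectation rests on compound 2 at 170 nM and compound 3 at 1200 nM, which show that changing the alkyl pattern on this ring can move the number well beyond the scatter. A modest weakening is expected, so the estimated step from compound 2 to compound 4 is a 1.8-fold higher number from compound 2 to compound 4 (0.25 log units; within the scatter). Compound 4 is expected to give about 300 nM, between 100 nM and 900 nM.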

Compound 4, half-maximal inhibitory concentration: 200 nM
Estimate against measurement, compound 4: 1.5-fold (0.18 log units) above, within the range that was stated.
By their numbers in this assay, from the lowest: compounds 2, 4 and 1 (each within the scatter of the next, the first and the last beyond it); then compound 3.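

Moving the same atoms around the five-membered ring, with 1,4,5-trimethyl-1H-imidazol-2-yl in place of 5-ethyl-1-methyl-1H-imidazol-2-yl, gives in this assay a 1.2-fold higher number from compound 2 to compound 4 (0.07 log units; within the scatter) and so leaves the two compounds indistinguishable. Among the compounds shown here, this is the first pair in the set that differs in only one place, and it shows that at this position, on an aromatic carbon ortho to a large group, this particular rearrangement of alkyl groups makes no difference the assay can resolve. Nothing measured here gives a reason for this result.

As far as these compounds go, it remains open whether this tolerance extends to groups of another kind on the same ring, such as a longer chain like n-butyl, an amine or a carboxylic acid. The compounds shown also cannot say whether the same rearrangement would read alike on a different version of the shared core.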